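Cytotoxicity notes on the step to compound 3

The source may hold more compounds than are shown below. What is called first, only, known or untested is meant among the compounds shown, and "the series" means these compounds.

Values so far in a toxicity assay on Vero cells (Chlorocebus sabaeus) for cytotoxicity, read by MTT assay; on this read-out higher numbers stand for weaker inhibition and lower numbers for stronger inhibition 
- compound 1 (`CC(C)OC(=O)NC(=O)c1ccsc1NC(=O)c1ccc(S(=O)(=O)N2CCOCC2)cc1`) gives 13.1 ug/mL 
- compound 2 (`O=C(NC(=O)c1ccsc1NC(=O)c1ccc(S(=O)(=O)N2CCOCC2)cc1)OCC(F)(F)F`) gives "nd" (no result reported) 
- compound 3 (`Cc1ccnc(NC(=O)c2ccsc2NC(=O)c2ccc(S(=O)(=O)N3CCOCC3)cc2)n1`) is still to be measured

Compound 2 has no place on the numbers: for compound 2 the entry in this assay stands as "nd" (no result reported) and gives no single value. Among the measured compounds shown here, the only number so far is that of compound 1 (13.1 ug/mL). The structural change under study is 4-methylpyrimidin-2-yl in place of (2,2,2-trifluoroethoxy)carbonyl on an amide-type nitrogen, which puts 4-methylpyrimidin-2-yl in place of (2,2,2-trifluoroethoxy)carbonyl on an amide-type nitrogen. For the measured compounds named here, no measured step shows what this change does, and the size of the step from compound 2 cannot be read from the data. Going by the values given here, no shift beyond the scatter from the one available number is expected, in either direction, and the range is kept wide. The estimated value for compound 3 is 15 ug/mL, with an expected range from 5 ug/mL to 60 ug/mL.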

Compound 3, half-maximal inhibitory concentration: 42.7 ug/mL
Estimate against measurement, compound 3: 2.8-fold (0.45 log units) below; measured number inside the range.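

In this assay, among the compounds shown here, the exchange of isopropoxycarbonyl for 4-methylpyrimidin-2-yl on an amide-type nitrogen gives a 3.3-fold higher number from compound 1 to compound 3 (0.51 log units; beyond the scatter) and so weaker inhibition of the cells, the first measured change at this position, showing that this nitrogen can carry an aromatic ring in place of a carbonyl-linked group without stronger inhibition on this read-out. The step from compound 2 to compound 3 cannot be read, as compound 2 has no single number. No measurement at hand accounts for the shift.

This single pair does not separate the contribution of the ring from that of the methyl group on it, or from the loss of the carbonyl. An unsubstituted pyrimidin-2-yl, a phenyl or a plain acetyl on the same nitrogen would address these questions.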